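Swapping hydroxy for (3-chlorophenyl)amino on a carbonyl carbon

This account rests on a few compounds, and the source may have more. Where it says the series, first, only, none or still open, it means among the compounds named here.

Measured so far:
compound 1 `CC(=O)SCCC(CCCCC(=O)O)SC(C)=O` gives 9.22%
compound 2 `O=C(CCCCC(S)CCS)Nc1ccc(Br)cn1` gives 23.2%

In a functional assay on Bel-7402 cells (Homo sapiens) for inhibition, read by MTT assay, with a stated time of 24 h, tested at 10 ug/mL (on this read-out higher numbers stand for more inhibition of growth at the one concentration tested and lower numbers for less inhibition of growth), compound 1 stands lowest of the two measured numbers at 9.22%. Compound 2 gives 23.2% on this read-out. The gap between these two numbers lies beyond the usual scatter. Compound 3 `CC(=O)SCCC(CCCCC(=O)Nc1cccc(Cl)c1)SC(C)=O` keeps the core of compound 1 and changes one place (3-chlorophenyl)amino in place of hydroxy on a carbonyl carbon with (3-chlorophenyl)amino in place of hydroxy on a carbonyl carbon. Among the measured compounds shown here, no measured pair isolates this change. Compound 2 also lacks that hydroxy but differs elsewhere too, so its value of 23.2% gives only loose guidance toward an upward step in this assay for the new compound. A moderate rise is expected, estimated as a number 12.8 percentage points higher from compound 1 to compound 3 (beyond the scatter) overall. Compound 3 is estimated at 22% with an expected range (8% to 42%).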

Compound 3, percent growth inhibition at one concentration: "not active" (no number reported)
Compound 3: no number reported, and the estimate cannot be compared.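

Among the compounds shown here, compound 3 was reported as "not active" without a number, so no step from compound 1 to compound 3 can be read. No evidence bears on this result. The compounds shown leave open how far (3-chlorophenyl)amino in place of hydroxy on a carbonyl carbon shifts growth inhibition.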